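The source may report more compounds than this note shows. Statements on the series, on what has been measured and on what is new or still open speak of the compounds shown alone.

compound 1 `CCn1c(N)c(-c2nc3ccccc3[nH]2)c2nc(C#N)c(C#N)nc21` - > 50000 nM
compound 2 `CCN(CC)CCn1c(N)c(-c2nc3ccccc3[nH]2)c2nc(C#N)c(C#N)nc21` - 11600 nM
compound 3 `CN1CCN(CCn2c(N)c(-c3nc4ccccc4[nH]3)c3nc(C#N)c(C#N)nc32)CC1` - > 50000 nM

In a functional assay on HeLa cells (Homo sapiens) for antiproliferative activity, read by MTT assay, with a stated time of 48 h (on this read-out lower numbers stand for stronger inhibition and higher numbers for weaker inhibition), compound 3 stands at > 50000 nM, a limit and not a number. Compound 4 `CCCn1c(N)c(-c2nc3ccccc3[nH]2)c2nc(C#N)c(C#N)nc21` replaces 2-(4-methylpiperazin-1-yl)ethyl with propyl: methyl in place of 4-methylpiperazin-1-yl on a saturated chain carbon, two bonds along the chain from an aromatic nitrogen. The measured steps at this place are an at least 4.3-fold lower number from compound 1 to compound 2 (0.63 log units; beyond the scatter), an at least 4.3-fold higher number from compound 2 to compound 3 (0.63 log units; beyond the scatter) and a step that the two limits leave unreadable from compound 1 to compound 3. Only compound 2 gives a number, and it carries diethylamino, which compound 4 lacks. Compound 1 is also a limit, at > 50000 nM, and this is the main reason to expect little activity from compound 4. The expected step is an at least 1.1-fold lower number from compound 3 to compound 4 (0.04 log units; that floor lies within the scatter), with no readable change beyond the scatter. For compound 4 the estimated value is 45000 nM, with an expected range of 15000 nM to 120000 nM.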

Compound 4, half-maximal inhibitory concentration: > 50000 nM
Compound 4: a limit, no number (the forecaster's own chance of this, stated with the estimate: 65%); middle value at least 1.1-fold (0.04 log units) from the limit.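

In this assay, methyl in place of diethylamino at this place gives an at least 4.3-fold higher number from compound 2 to compound 4 (0.63 log units; beyond the scatter), so the propyl group does not keep the activity seen with the diethylamino group. Compound 2 remains the only compound shown with a number, while compound 4 gives only a limit. The steps to compound 4 from compound 1 and compound 3 cannot be read, because both ends of each are limits: the limit of > 50000 nM in this assay, at which 3 of the 4 values shown sit. Still open, on these data alone, is whether another amine on the same chain, such as pyrrolidin-1-yl or morpholin-4-yl, gives a number, and whether diethylamino on a longer chain does.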